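The source may report more compounds than this note shows. Statements on the series, on what has been measured and on what is new or still open speak of the compounds shown alone.

Measured so far in a functional assay on COLO 205 cells (Homo sapiens) for cytotoxicity, read by sulforhodamine B assay, with a stated time of 48 h; a higher number here means a weaker inhibitor of growth, a lower number a stronger inhibitor of growth:
- Compound 1 `COc1cc(C(=O)c2ccc(OC)c(O)c2OC)cc(OC)c1O`: 4830 nM
- Compound 2 `COc1cc(C(=O)c2ccc3c(c2)oc(=O)n3S(C)(=O)=O)cc(OC)c1OC`: 2500 nM

These two values lie within the usual scatter of repeated measurements, so the data do not rank compound 1 against compound 2. Both compounds show growth inhibition in the micromolar range, and neither stands apart.

The next compound to be tested is compound 3 `COc1ccc(C(=O)c2cc(OC)c(OC)c(OC)c2)c(OC)c1O`. It comes from compound 1 through one small change: methyl in place of hydrogen on an oxygen on an aromatic ring, turning a hydroxy into a methoxy. Among the measured compounds shown here, no measured pair shows this change, so any forecast here is loose. With the new methoxy, the altered part of compound 3 matches the corresponding part of compound 2, which gives 2500 nM. That gives only weak guidance, yet a move towards a lower number, meaning stronger growth inhibition, seems more likely than a move towards a higher one. The expected change is a 6.0-fold lower number from compound 1 to compound 3 (0.78 log units; beyond the scatter). For compound 3 the estimated value is 800 nM, with an expected range from 60 nM to 5000 nM.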

Compound 3, concentration for 50% growth inhibition: 6200 nM
Compound 3: middle estimate off by 7.8-fold (0.89 log units), on the low side; the measured number lies above the stated range.
By their numbers in this assay, from the lowest: compounds 2, 1 and 3 (each within the scatter of the next, the first and the last beyond it).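

In this assay, methyl in place of hydrogen on an oxygen on an aromatic ring, turning a hydroxy into a methoxy, gives a 1.3-fold higher number from compound 1 to compound 3 (0.11 log units; within the scatter), so this first measured pair for the change shows no separation between the two compounds. At this position, then, the free hydroxy of compound 1 is not needed to keep growth inhibition in the micromolar range, and the added methyl brings no measurable gain or loss in this cell assay. Among the compounds shown here, nothing measured so far accounts for how little this swap matters, and a single pair cannot show whether the same holds at any other hydroxy on the core.

From the compounds shown here alone, it remains open whether this oxygen tolerates something larger than methyl, such as an ethyl group or a longer chain, and what an amine or a fluorine in place of the hydroxy would do to the number. Also open, going by these compounds, is what happens if the hydroxy that compound 3 still carries on its other aromatic ring becomes a methoxy too.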